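The compounds below may be only part of what the source reports. "The series", "measured", "known", "first", "only" and "open" are said of these compounds alone.

Of the compounds shown here, three of one family have been measured in a functional assay on MCF cells (Homo sapiens) for cytotoxicity, read by sulforhodamine B assay, with a stated time of 24 h (a higher number here means a weaker inhibitor, a lower number a stronger inhibitor), and a fourth awaits its number. Compound 1 `Cc1ccc(NC(=S)Nn2c(S)nnc2-c2ccncc2)cc1` gives 2170 nM. Compound 2 `S=C(Nc1ccc(Br)cc1)Nn1c(S)nnc1-c1ccncc1` differs from compound 1 by a single change, (bromo in place of methyl on an aromatic carbon), and the step it made is a 1.4-fold lower number from compound 1 to compound 2 (0.14 log units; within the scatter). In this assay compound 2 gives 1590 nM. Compound 3 `Cc1ccc(Nc2nn3c(-c4ccncc4)nnc3s2)cc1` is built on a different core; the difference between the two cores is not broken down here. In this assay compound 3 gives 120 nM, the lowest of the three numbers, and its gaps to compound 2 and to compound 1 both lie beyond the scatter of repeated measurements.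

Compound 4 `Brc1ccc(Nc2nn3c(-c4ccncc4)nnc3s2)cc1` stands to compound 3 as compound 2 stands to compound 1: the change is bromo in place of methyl on an aromatic carbon, the same change, at the same place, as between compound 1 and compound 2. Among these four compounds this change occurs twice in all. The one time it has been measured, it moved the number only a little, and that movement was within the scatter. On that single precedent, the step from compound 3 to compound 4 is expected to be about a 1.2-fold lower number from compound 3 to compound 4 (0.08 log units; within the scatter), resting on the measured step from compound 1 to compound 2 a 1.4-fold lower number from compound 1 to compound 2 (0.14 log units; within the scatter). Compound 4 is therefore estimated to give 100 nM in this assay, with a range from 40 nM to 250 nM, and the measurement itself is reported next.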

Compound 4, half-maximal inhibitory concentration: 229 nM
The estimate for compound 4 lay 2.3-fold (0.36 log units) below the measured number, and the stated range covers the measured number.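

In this assay, putting bromo in place of methyl on the aromatic ring, the change from 4-methylphenyl to 4-bromophenyl, gave a 1.9-fold higher number from compound 3 to compound 4 (0.28 log units; within the scatter), so on this second core the change again made no difference that stands out from ordinary repeat-to-repeat variation. Set side by side, the steps on the two cores do not differ by more than such variation allows: the same change on two cores in this assay, a 1.4-fold lower number (0.14 log units; within the scatter) from compound 1 to compound 2 and a 1.9-fold higher number (0.28 log units; within the scatter) from compound 3 to compound 4, 2.6-fold (0.42 log units) apart, within the scatter of two such steps. This shows that in these two pairs the change stayed small on both cores, so carrying it from one core to the other gave no sign of a different outcome, but the opposite directions printed for the two steps should not be read as a real reversal, and two small steps in a single assay do not prove that the two cores respond alike to every change, or that this one would stay small on a third core.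

The compounds shown carry only methyl or bromo at this place, so it remains open whether an amine, a carboxylic acid or a methoxy group on that same aromatic carbon would move the number beyond the scatter. As far as these compounds go, it also remains open whether either core would respond to such groups in the same way as the other.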